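Hydroxy to methoxy on compound 1: expected activity

This account rests on a few compounds, and the source may have more. Where it says the series, first, only, none or still open, it means among the compounds named here.

Measured so far:
- compound 1, `O=C(Nc1cccc(-n2cc(-c3ccncc3)c(-c3cc(O)cc(Cl)c3)n2)c1)Nc1ccc(Cl)c(C(F)(F)F)c1`: -38% in a functional assay on CAKI-1 cells (Homo sapiens) for inhibition, read by sulforhodamine B assay, with a stated time of 48 h, tested at 100 uM; a higher number here means a weaker effect of the compound at the concentration tested, a lower number a stronger effect
- compound 2, `O=C(Nc1cccc(-n2cc(-c3ccncc3)c(-c3cc(O)cc(Cl)c3)n2)c1)Nc1ccc(Cl)c(Cl)c1`: -12% in this assay

Compound 1 gives the lowest of the two numbers in this assay; the nearest is compound 2, reached by a number 26 percentage points higher from compound 1 to compound 2 (beyond the scatter). That single measured step concerns a different part of the molecule, chloro in place of trifluoromethyl on an aromatic carbon, and not the oxygen changed below.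

Compound 3, `COc1cc(Cl)cc(-c2nn(-c3cccc(NC(=O)Nc4ccc(Cl)c(C(F)(F)F)c4)c3)cc2-c2ccncc2)c1`, is the next compound for this assay. It differs from compound 1 in one place: methyl in place of hydrogen on an oxygen on an aromatic ring. For the measured compounds named here, no measured step touches this oxygen, so no measured number bears directly on the change; the one step available sits elsewhere and is of modest size. Going by the values given here, with no comparable precedent, the expectation for this assay is a step that stays within the usual scatter, a number 10 percentage points higher from compound 1 to compound 3 (within the scatter), leaning if anything toward a slightly weaker effect. Compound 3 is therefore estimated at -28%, with a range from -60% to 5%.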

Compound 3, a percentage reported as activity, at one concentration (the size of the read-out at that concentration, not a potency): -40%
The estimate for compound 3 lay 12 percentage points above the measured number; the range from low to high includes it.
By their numbers in this assay, from the lowest: compounds 3 and 1 (each within the scatter of the next); then compound 2.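

In this assay, hydroxy to methoxy gives a number 2 percentage points lower from compound 1 to compound 3 (within the scatter), so with trifluoromethyl kept in place, the hydrogen on this oxygen is not required for the read-out at the concentration tested, and methyl is tolerated here. For the compounds shown here, the only earlier step, a number 26 percentage points higher from compound 1 to compound 2 (beyond the scatter), lies in a different part of the molecule and went beyond the scatter, whereas this first step at the oxygen does not, so the series now has one substitution that registers and one that cannot be distinguished from no difference. No measurement on these compounds speaks to why the methyl group leaves the reading within the scatter.

From the compounds shown here alone, this rests on a single pair, so it remains open whether a longer chain on the oxygen, such as ethoxy or benzyloxy, or an amine in place of the hydroxy group would also stay within the scatter. Going by these compounds, it is also open whether methoxy would read the same way alongside the chloro group of compound 2, since the tolerance seen here belongs to the trifluoromethyl series alone.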